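Flipping one stereocentre in a legumain nitrile inhibitor

The source may hold more compounds than are shown below. What is called first, only, known or untested is meant among the compounds shown, and "the series" means these compounds.

For the measured compounds named here, compound 2 `C[C@@H](C(=O)N[C@H](C#N)CC(N)=O)N(Cc1ccc(-c2ccc(F)c(F)c2)cc1)S(C)(=O)=O` stands as the lower of the two numbers known so far: in an assay on isolated protein for inhibition of legumain (Homo sapiens), with stated times of 2 min and 60 min (a higher number here means a weaker inhibitor, a lower number a stronger inhibitor), compound 2 gives 252 nM, whereas compound 1 `CC(C)Oc1cccc(-c2ccc(CN([C@H](C)C(=O)N[C@H](C#N)CC(N)=O)S(C)(=O)=O)cc2)c1` gives 5050 nM, a gap beyond the scatter. Compound 3 `C[C@H](C(=O)N[C@H](C#N)CC(N)=O)N(Cc1ccc(-c2ccc(F)c(F)c2)cc1)S(C)(=O)=O` has not been measured. It differs from compound 2 in this way: the two compounds have the same atoms and bonds and differ only in configuration as drawn: 1 of 2 stereo elements differ; a stereocentre at a saturated chain carbon is drawn S in compound 2 and R in compound 3. Going by the values given here, no pair of measured compounds isolates such a change, so the direction rests on expectation alone. A weakening step is expected, a 6.0-fold higher number from compound 2 to compound 3 (0.77 log units; beyond the scatter), beyond the scatter. For compound 3 the estimate in this assay is 1500 nM, with a range from 400 nM to 6000 nM.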

Compound 3, half-maximal inhibitory concentration: 6300 nM
Compound 3: middle estimate off by 4.2-fold (0.62 log units), on the low side, outside the stated range (above it).
By their numbers in this assay, from the lowest: compound 2; then compounds 1 and 3 (each within the scatter of the next).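

In this assay, turning the stereocentre at the saturated chain carbon from S to R is a large change on its own (a 25-fold higher number from compound 2 to compound 3 (1.40 log units; beyond the scatter)), and that step belongs to this centre alone: the fact that compounds 2 and 3 differ only in the configuration as drawn. With the stereocentre drawn R, 3,4-difluorophenyl in place of 3-isopropoxyphenyl makes no difference beyond the scatter (a 1.2-fold higher number from compound 1 to compound 3 (0.10 log units; within the scatter)). The compounds shown leave open how 3-isopropoxyphenyl behaves with the stereocentre drawn S. They also leave open whether an ethyl group or an amine on this carbon would keep the stronger inhibition of compound 2.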